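From phenyl to 2-methoxyphenyl in the series

The source may hold more compounds than are shown below. What is called first, only, known or untested is meant among the compounds shown, and "the series" means these compounds.

Three compounds on the shared core have numbers in a functional assay on U-937 cells (Homo sapiens) for cytotoxicity, read by MTT assay, with a stated time of 24 h; on this read-out higher numbers stand for weaker inhibition and lower numbers for stronger inhibition. Compound 1 `CC(C)(C)OC(=O)N1CCCN(CCCCCOc2c(Br)cc(Br)cc2Oc2ccc(Br)cc2Br)CC1` gives 39.5 ug/mL. Compound 2 `CN1CCN(CCCCCOc2c(Br)cc(Br)cc2Oc2ccc(Br)cc2Br)CC1` gives 49.1 ug/mL. Compound 3 `Brc1ccc(Oc2cc(Br)cc(Br)c2OCCCCCN2CCN(c3ccccc3)CC2)c(Br)c1` gives 42.5 ug/mL. All three values lie within the scatter of one another, so compound 3 has no meaningful rank among them.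

Compound 4 `COc1ccccc1N1CCN(CCCCCOc2c(Br)cc(Br)cc2Oc2ccc(Br)cc2Br)CC1` has not yet been measured. It carries 2-methoxyphenyl where compound 3 carries phenyl: methoxy in place of hydrogen on an aromatic carbon. This places methoxy in place of hydrogen on an aromatic carbon, ortho to a large group.

Among the compounds with values here, one measured step bears on this change, and only indirectly: a 1.2-fold lower number from compound 2 to compound 3 (0.06 log units; within the scatter). It replaces methyl with phenyl on an amine nitrogen in a ring, the same nitrogen that holds the 2-methoxyphenyl in compound 4. That step stays within the scatter. Within the data shown here, no measured compound carries a group on this phenyl, so the data offer no direct precedent for the change and favour no direction.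

The expected change is a 1.0-fold lower number from compound 3 to compound 4 (0.01 log units; within the scatter), with no step beyond the scatter anticipated in this assay. For compound 4 the estimated value is 42 ug/mL, with an expected range of 26 ug/mL to 66 ug/mL.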

Compound 4, half-maximal inhibitory concentration: 37.5 ug/mL
The estimate for compound 4 lay 1.1-fold (0.05 log units) above the measured number; the measured number falls inside the stated range.
By their numbers in this assay, from the lowest: compounds 4, 1, 3 and 2 (each within the scatter of the next).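

Within the data shown here, the methoxy group gives the first direct reading of a substituent on this phenyl: in this assay, placing it on an aromatic carbon, ortho to a large group, gives a 1.1-fold lower number from compound 3 to compound 4 (0.05 log units; within the scatter) and stays within the scatter. The larger replacement on the amine nitrogen in a ring, 2-methoxyphenyl in place of methyl, also stays within the scatter (a 1.3-fold lower number from compound 2 to compound 4 (0.12 log units; within the scatter)), as did phenyl in place of methyl (a 1.2-fold lower number from compound 2 to compound 3 (0.06 log units; within the scatter)). In this assay, this position therefore tolerates methoxy without a readable shift, although that reading rests on a single substituent at a single site on the phenyl; no accompanying measurement offers an account of this result.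

The compounds shown leave open whether any group on this phenyl, such as a carboxylic acid or a primary amine, would produce a step beyond the scatter. They also leave open whether a change elsewhere, such as a longer chain on the ring nitrogen or a hydroxyl in place of the methoxy, would separate any compound from the others in this assay.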